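This account rests on a few compounds, and the source may have more. Where it says the series, first, only, none or still open, it means among the compounds named here.

Measured compounds:
compound 1 `CC(C(=O)NCc1ccc(C(C)(C)C)nc1SCCCN1CCCC1)c1ccc(NS(C)(=O)=O)c(F)c1` — 17.1 nM
compound 2 `CC(C(=O)NCc1ccc(C(C)(C)C)nc1SCc1ccccc1Cl)c1ccc(NS(C)(=O)=O)c(F)c1` — 3.8 nM
compound 3 `CCCCN(C)c1cc(C(C)(C)C)ccc1CNC(=O)C(C)c1ccc(NS(C)(=O)=O)c(F)c1` — 1 nM

In an assay on cells for antagonist activity at transient receptor potential cation channel subfamily V member 1 (Homo sapiens), read by FLIPR and calcium flux, with a stated time of 6 min (on this read-out lower numbers stand for stronger inhibition and higher numbers for weaker inhibition), compound 3 stands lowest of the three; compound 2 sits nearer to it than compound 1 does, and both gaps are beyond the scatter. Compound 4 `CC(C(=O)NCc1ccc(C(C)(C)C)cc1SC1CCCCC1)c1ccc(NS(C)(=O)=O)c(F)c1` is not yet measured. It differs from compound 3 by cyclohexylsulfanyl in place of butyl(methyl)amino on an aromatic carbon. Among the measured compounds shown here, no measured step covers this exact exchange. For the measured compounds named here, the one measured step, a 4.5-fold lower number from compound 1 to compound 2 (0.65 log units; beyond the scatter), concerns a change of the group carried on a sulfur within a different core and shows that this position tolerates sizeable shifts. Because compound 3 gives 1 nM and the sulfur-bearing compounds 1 and 2 give higher numbers, a modest rise is expected, a 5.0-fold higher number from compound 3 to compound 4 (0.70 log units; beyond the scatter). For compound 4 the estimated value is 5 nM, expected between 1.5 nM and 15 nM.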

Compound 4, inhibition constant: 7.4 nM
Beside the measured number, compound 4's estimate is 1.5-fold (0.17 log units) below it; measured number inside the range.
By their numbers in this assay, from the lowest: compound 3; then compounds 2 and 4 (each within the scatter of the next); then compound 1.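

In this assay, butyl(methyl)amino giving way to cyclohexylsulfanyl on this aromatic carbon produces a 7.4-fold higher number from compound 3 to compound 4 (0.87 log units; beyond the scatter). Compounds 1 and 2 varied only the group carried on sulfur in another core, whereas this step changes the atom bound to the aromatic carbon as well as the group, and compound 4 still gives 7.4 nM in this series. Nothing available explains the rise. As far as these compounds go, whether it follows the sulfur or the cyclohexyl ring stays open: cyclohexylamino and butylsulfanyl on this carbon would separate the two. From the compounds shown here alone, whether the exchange reads the same in the core of compound 1 also remains open.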